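The compounds below may be only part of what the source reports. "The series", "measured", "known", "first", "only" and "open" are said of these compounds alone.

Values in an ADME assay on microsomes from liver (Rattus norvegicus) for metabolic stability (on this read-out lower numbers stand for slow clearance and higher numbers for fast clearance), so far
- compound 1 `CCCC(C#N)(CC)Nc1nc(NC)nc(-n2cncn2)n1` gives 29 mL/min/kg
- compound 2 `CNc1nc(NC2(C#N)CCCCC2)nc(-n2ccnc2)n1` gives 52 mL/min/kg
- compound 3 `CNc1nc(NC2(C#N)CCCCC2C)nc(-n2cncn2)n1` gives 86 mL/min/kg

Compound 2 lies within the usual scatter of both compound 1 and compound 3, so these numbers do not resolve its place among the three. Compound 4 `CNc1nc(C#N)nc(NC2(C#N)CCCCC2)n1` is not yet measured. Among the compounds with values here, it carries cyano in place of 1H-imidazol-1-yl on an aromatic carbon of compound 2 cyano in place of 1H-imidazol-1-yl on an aromatic carbon and no measured pair shows this exchange. Within the data shown here, the only anchor is therefore compound 2 at 52 mL/min/kg and no step beyond the scatter is expected, the estimate being a 1.2-fold lower number from compound 2 to compound 4 (0.06 log units; within the scatter) in this assay with wide uncertainty. The estimated value for compound 4 is 45 mL/min/kg with an expected range from 18 mL/min/kg to 100 mL/min/kg.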

Compound 4, clearance: 122 mL/min/kg
For compound 4 the middle estimate is 2.7-fold (0.43 log units) below the measured one, and the stated range ends below it.
By their numbers in this assay, from the lowest: compounds 1, 2, 3 and 4 (each within the scatter of the next, the first and the last beyond it).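

In this assay, cyano in place of 1H-imidazol-1-yl on the aromatic carbon opposite the ring nitrogen gives a 2.3-fold higher number from compound 2 to compound 4 (0.37 log units; beyond the scatter). Within the data shown here, this is the first one-place step, and it shows that the group on this carbon can move clearance beyond the scatter, though only modestly. Nothing available bears on why the number rises.

Going by these compounds, from this single pair, it remains open whether the step follows the loss of 1H-imidazol-1-yl or the entry of cyano. A methoxy or dimethylamino group on this carbon would help separate the two.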